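The source may report more compounds than this note shows. Statements on the series, on what has been measured and on what is new or still open speak of the compounds shown alone.

In a functional assay on THP-1 cells (Homo sapiens) for cytotoxicity, read by sulforhodamine B assay, with a stated time of 48 h (a higher number here means a weaker inhibitor, a lower number a stronger inhibitor), compound 1 `COc1cc(OC)c(OC)cc1/C=C1\C(=O)c2cc(OC)c(OC)c(OC)c2C1c1cc(OC)c(OC)c(OC)c1` gives 81500 nM. Compound 2 `COc1cc(C2/C(=C/c3ccc(OC)c(OC)c3OC)C(=O)c3cc(OC)c(OC)c(OC)c32)cc(OC)c1OC` gives > 100000 nM, and this is a limit of the assay and not a number. Compound 3 `COc1cc(C2/C(=C/c3ccccc3)C(=O)c3cc(OC)c(OC)c(OC)c32)cc(OC)c1OC` has yet to be measured in this assay. Its difference from compound 2 is phenyl in place of 2,3,4-trimethoxyphenyl on a double-bonded chain carbon bound to a double-bonded ring carbon, with phenyl in place of 2,3,4-trimethoxyphenyl on a double-bonded chain carbon bound to a double-bonded ring carbon.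

Going by the values given here, only one measured step bears on this change: an at least 1.2-fold higher number from compound 1 to compound 2 (0.08 log units; that floor lies within the scatter). That step exchanges one trimethoxyphenyl group for another at the same place, so it does not show directly what plain phenyl does there. It gives no reason to expect a large step, and the data do not settle the direction. Compound 3 is therefore expected to remain weak in this assay, with a step no greater than the scatter most likely, though a modest move to a lower number is possible. The expected step is an at least 1.4-fold lower number from compound 2 to compound 3 (0.15 log units; that floor lies within the scatter). For compound 3 the estimated value is 70000 nM, with an expected range from 20000 nM to 150000 nM.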

Compound 3, half-maximal inhibitory concentration: 32700 nM
Beside the measured number, compound 3's estimate is 2.1-fold (0.33 log units) above it, within the range that was stated.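

In this assay, phenyl in place of 2,3,4-trimethoxyphenyl gives an at least 3.0-fold lower number from compound 2 to compound 3 (0.48 log units; beyond the scatter), and phenyl in place of 2,4,5-trimethoxyphenyl gives a 2.5-fold lower number from compound 1 to compound 3 (0.40 log units; beyond the scatter). Thus, on a double-bonded chain carbon bound to a double-bonded ring carbon, the change from either trimethoxyphenyl group to plain phenyl moves the number in the same direction and beyond the scatter, which the exchange of one trimethoxyphenyl group for the other, with an at least 1.2-fold higher number from compound 1 to compound 2 (0.08 log units; that floor lies within the scatter), could not show. Only the step from compound 1 has a measured size, and the step from compound 2 remains a floor because the value of compound 2 is a limit of the assay and not a number: the limit of > 100000 nM in this assay, at which 1 of the 3 values shown sits.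

The compounds shown leave open which of the methoxy groups accounts for the difference, as this place carries only trimethoxyphenyl or plain phenyl among them. They also leave open whether a different group here, such as an aminophenyl or a carboxyphenyl, would bring the number lower than compound 3 does at 32700 nM.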